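Chloro in place of trifluoromethyl: notes on compound 4

This account rests on a few compounds, and the source may have more. Where it says the series, first, only, none or still open, it means among the compounds named here.

In a functional assay on LOX IMVI cells (Homo sapiens) for inhibition, read by sulforhodamine B assay, with a stated time of 48 h (a lower number here means a stronger inhibitor of growth, a higher number a weaker inhibitor of growth), compound 1 (`COc1cc2nc(-c3ccc(Cl)cc3)cc(OCCCN3CCC(O)CC3)c2cc1OC`) gives 589 nM, compound 2 (`COc1cc2nc(-c3ccc(Cl)cc3)cc(OCCCN3CCCC3)c2cc1OC`) gives 446 nM and compound 3 (`COc1cc2nc(-c3ccc(C(F)(F)F)cc3)cc(OCCCN3CCCCC3)c2cc1OC`) gives 355 nM. Compound 3 lies within the scatter of both other compounds, so the three numbers do not separate.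

Compound 4 (`COc1cc2nc(-c3ccc(Cl)cc3)cc(OCCCN3CCCCC3)c2cc1OC`) differs from compound 3 in one place: chloro in place of trifluoromethyl on an aromatic carbon, para to a large group (chloro in place of trifluoromethyl on an aromatic carbon). Going by the values given here, no measured step covers this exchange. Among the compounds with values here, the only measured step, a 1.3-fold lower number from compound 1 to compound 2 (0.12 log units; within the scatter), puts pyrrolidin-1-yl in place of 4-hydroxypiperidin-1-yl at the end of the chain, and it stays within the scatter. Compound 1 and compound 2 already carry the chloro, while compound 4 keeps the chain end of compound 3. With chloro present, compound 2 still gives 446 nM, a value within the scatter of compound 3. No step beyond the scatter is therefore expected in this assay, and no direction is favoured. The estimate corresponds to an expected step of a 1.2-fold higher number from compound 3 to compound 4 (0.07 log units; within the scatter). Compound 4 is estimated at 420 nM, with an expected range of 210 nM to 840 nM.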

Compound 4, concentration for total growth inhibition: 435 nM
Estimate against measurement, compound 4: 1.0-fold (0.02 log units) below; measured number inside the range.
By their numbers in this assay, from the lowest: compounds 3, 4, 2 and 1 (each within the scatter of the next).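

In this assay the change from 4-(trifluoromethyl)phenyl to 4-chlorophenyl now has a measured step of its own: a 1.2-fold higher number from compound 3 to compound 4 (0.09 log units; within the scatter) shows that, with the piperidin-1-yl chain end held constant, chloro and trifluoromethyl do not separate at this aromatic carbon. With chloro held constant, the chain end gives two further readings, with piperidin-1-yl in place of pyrrolidin-1-yl as a 1.0-fold lower number from compound 2 to compound 4 (0.01 log units; within the scatter) and hydrogen in place of hydroxy on a saturated ring carbon as a 1.4-fold lower number from compound 1 to compound 4 (0.13 log units; within the scatter), and both stay within the scatter, so none of the three single changes among these four compounds moves the number beyond it. No evidence at hand bears on this result.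

Only chloro and trifluoromethyl are shown at this position, so it remains open whether a nitrile, a methoxy group or a carboxylic acid there would separate from them. The chain end is equally open, both for a morpholine or a piperazine in place of the rings shown and for a longer chain between the oxygen and the ring.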